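The source may report more compounds than this note shows. Statements on the series, on what has been measured and on what is new or still open speak of the compounds shown alone.

Working notes on the series.

Among the compounds with values here, compound 1, `COc1cc(-c2ccnc3cc(-c4ccc5cc[nH]c5c4)nn23)cc(OC)c1OC`, is the only member with a full number in a functional assay on HCT-116 cells (Homo sapiens) for inhibition, read by CCK-8 assay, with a stated time of 48 h; on this read-out higher numbers stand for weaker inhibition and lower numbers for stronger inhibition; in this assay compound 1 gives 187 nM. Compound 2, `COc1ccc(-c2cc3nccc(-c4cc(OC)c(OC)c(OC)c4)n3n2)cc1[N+](=O)[O-]`, shares the core of compound 1 but carries a different aryl group on it. In this assay compound 2 gives only > 10000 nM, which is a limit of the measurement and not a number; compound 2 therefore stands at the limit of > 10000 nM in this assay, at which 1 of the 2 values shown sits. Within the data shown here, no step between two measured compounds can be stated here, and the two values shown are read only as a full number for compound 1 and a limit for compound 2.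

Compound 3, `COc1ccc(-c2cc3nccc(-c4cc(OC)c(OC)c(OC)c4)n3n2)cc1F`, differs from compound 2 in one place: fluoro in place of nitro on an aromatic carbon. The fluoro sits ortho to a methoxy group and meta to a large group. As compound 2 sits at a limit, any step from compound 2 to compound 3 can be sized only against that limit. The expectation is a step toward stronger inhibition, an at least 2.0-fold lower number from compound 2 to compound 3 (0.30 log units; that floor lies within the scatter), without certainty that it leaves the scatter. Compound 3 is estimated at 5000 nM, with a range from 1000 nM to 20000 nM.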

Compound 3, half-maximal inhibitory concentration: 2840 nM
For compound 3 the middle estimate is 1.8-fold (0.25 log units) above the measured one; low and high end bracket the measured number.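

In this assay, fluoro in place of nitro on this aromatic carbon, ortho to a methoxy group and meta to a large group, gives an at least 3.5-fold lower number from compound 2 to compound 3 (0.54 log units; beyond the scatter), so this position tolerates a change that turns a limit into a full number. The true size of that step stays unknown, because compound 2 is held at a limit and not a number: the limit of > 10000 nM in this assay, at which 1 of the 3 values shown sits.

Within the data shown here, the full number also allows the first sized comparison of the aryl groups on the shared core, as 3-fluoro-4-methoxyphenyl in place of 1H-indol-6-yl gives a 15-fold higher number from compound 1 to compound 3 (1.18 log units; beyond the scatter), and so fluoro at this position does not close the gap to the 1H-indol-6-yl group.

The compounds shown leave open whether the step comes from the presence of fluoro or simply from the loss of nitro, a question that plain hydrogen, an amine or a nitrile on the same carbon would help to settle. Also open, from the compounds shown here alone, is how much of the gap to the 1H-indol-6-yl group can be recovered on the phenyl ring, for instance with a hydroxy group in place of the methoxy group.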